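The source may report more compounds than this note shows. Statements on the series, on what has been measured and on what is new or still open speak of the compounds shown alone.

In a functional assay on HeLa cells (Homo sapiens) for cytotoxicity, read by MTT assay, with a stated time of 24 h (on this read-out higher numbers stand for weaker inhibition and lower numbers for stronger inhibition), compound 1 `COc1cc(/C=C(\C#N)C(=O)N/N=C(\C)c2c(O)c3ccc(O)cc3oc2=O)ccc1O` gives 10500 nM and compound 2 `COc1cc(/C=C(\C#N)C(=O)N/N=C(\C)c2c(O)c3ccc(O)cc3oc2=O)cc(OC)c1OC` gives 18500 nM so the two stand within the scatter of each other. Compound 3 `C/C(=N\NC(=O)/C(C#N)=C/c1ccc(N(C)C)cc1)c1c(O)c2ccc(O)cc2oc1=O` has not yet been measured. It carries 4-(dimethylamino)phenyl in place of 4-hydroxy-3-methoxyphenyl on a double-bonded chain carbon bound to a double-bonded chain carbon. Going by the values given here, no measured step isolates this change, so no shift beyond the scatter is expected in this assay in either direction. The expected step runs a 1.1-fold higher number from compound 1 to compound 3 (0.06 log units; within the scatter) and stays small. Compound 3 is expected at 12000 nM with 5000 nM to 30000 nM as its estimated range.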

Compound 3, half-maximal inhibitory concentration: 5140 nM
Beside the measured number, compound 3's estimate is 2.3-fold (0.37 log units) above it; low and high end bracket the measured number.
By their numbers in this assay, from the lowest: compound 3; then compounds 1 and 2 (each within the scatter of the next).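

In this assay 4-(dimethylamino)phenyl in place of 4-hydroxy-3-methoxyphenyl on a double-bonded chain carbon bound to a double-bonded chain carbon gives a 2.0-fold lower number from compound 1 to compound 3 (0.31 log units; beyond the scatter) and this modest step shows that the group at this position can move the number beyond the scatter, which compounds 1 and 2 did not show. The swap keeps the heavy-atom count and removes the hydrogen-bond donor. Nothing measured bears on why the number moves. Open, going by these compounds, is whether the step comes from the dimethylamino group entering or from the hydroxy and methoxy groups leaving. Also open, on these data alone, is how an unsubstituted amine or a carboxylic acid on that phenyl ring would read.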